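The source may hold more compounds than are shown below. What is called first, only, known or untested is meant among the compounds shown, and "the series" means these compounds.

Compound 1 `O=C(NCc1cn(Cc2ccc(Cl)cc2)nn1)c1cn(-c2ccccc2)nc1-c1ccc(F)cc1`, compound 2 `COc1ccc(Cn2cc(CNC(=O)c3cn(-c4ccccc4)nc3-c3ccc(F)cc3)nn2)cc1` and compound 3 `O=C(NCc1cn(Cc2ccc(F)cc2)nn1)c1cn(-c2ccccc2)nc1-c1ccc(Cl)cc1` share a common core and differ only in the small groups on their outer rings. In a functional assay on MCF7 cells (Homo sapiens) for antiproliferative activity, read by sulforhodamine B assay, with a stated time of 48 h (on this read-out higher numbers stand for weaker inhibition of growth and lower numbers for stronger inhibition of growth), compound 1 gives 130 nM. Compound 2 differs from compound 1 by methoxy in place of chloro on an aromatic carbon, and in this assay compound 2 gives 650 nM, so that this change made a 5.0-fold higher number from compound 1 to compound 2 (0.70 log units; beyond the scatter). Compound 3 has the same atoms as compound 1, joined differently; the difference between the two cores is not broken down here. In this assay compound 3 gives 570 nM, a number close to that of compound 2.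

Compound 4 `COc1ccc(-c2nn(-c3ccccc3)cc2C(=O)NCc2cn(Cc3ccc(F)cc3)nn2)cc1` has not yet been measured. It differs from compound 3 by methoxy in place of chloro on an aromatic carbon, the same change that was made from compound 1 to compound 2, though on a ring that is joined to the core in a different way. Going by the values given here, with only one earlier instance of this change, and that on a different ring, the expectation is uncertain. Because the step of a 5.0-fold higher number from compound 1 to compound 2 (0.70 log units; beyond the scatter) was beyond the scatter, compound 4 is expected to give a higher number than compound 3, with a step of about a 3.5-fold higher number from compound 3 to compound 4 (0.55 log units; beyond the scatter). On that basis compound 4 is estimated at 2000 nM in this assay, with a plausible range from 700 nM to 6000 nM.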

Compound 4, concentration for 50% growth inhibition: 460 nM
Estimate against measurement, compound 4: 4.3-fold (0.64 log units) above, and the stated range ends above it.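

In this assay, putting methoxy in place of chloro on the 4-chlorophenyl ring gives a 1.2-fold lower number from compound 3 to compound 4 (0.09 log units; within the scatter), so here the swap leaves no change that can be told from ordinary repeat-to-repeat variation. Set beside the earlier pair, the same swap clearly does not carry over with the same size from one core to the other, and a large step in one pair gave no reliable forecast for the other: the same change on two cores in this assay, a 5.0-fold higher number (0.70 log units; beyond the scatter) from compound 1 to compound 2 and a 1.2-fold lower number (0.09 log units; within the scatter) from compound 3 to compound 4, 6.2-fold (0.79 log units) apart, beyond the scatter of two such steps. This shows only that the effect of the swap depends on its setting in these four compounds; it does not show why, since the two pairs differ both in their cores and in which ring carries the swap, and two pairs cannot separate those two differences or set a rule for any further core.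

The compounds shown leave open how a hydroxyl, an amine or a trifluoromethyl in place of chloro would behave on each of the two rings, and whether such groups would also give steps that differ between the cores. They also leave open whether a further pair with the same methoxy-for-chloro swap would follow compound 1 and compound 2 or compound 3 and compound 4.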